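Aryl variation on the shared core, T47D growth inhibition

The compounds below may be only part of what the source reports. "The series", "measured", "known", "first", "only" and "open" are said of these compounds alone.

Measured so far in a functional assay on T47D cells (Homo sapiens) for inhibition, read by sulforhodamine B assay, with a stated time of 48 h, tested at 10 uM; on this read-out lower numbers stand for less inhibition and higher numbers for more inhibition at the one concentration tested (going by the name of the read-out):
compound 1 `O=Cc1ccc(-c2cn3ccnc3c(-c3ccc4ncn(C5CCCCC5)c4c3)n2)cc1` gives 98%
compound 2 `Fc1ccc(-c2cn3ccnc3c(-c3ccc4ncn(C5CCCCC5)c4c3)n2)cc1` gives 33.3%
compound 3 `c1cn2cc(-c3ccsc3)nc(-c3ccc4ncn(C5CCCCC5)c4c3)c2n1` gives 63.7%

Compound 3 stands second highest of the three in this assay, with compound 2 nearest below it and compound 1 furthest above it, both gaps beyond the scatter. Compound 4 `COc1ccccc1-c1cn2ccnc2c(-c2ccc3ncn(C4CCCCC4)c3c2)n1` differs from compound 3 by 2-methoxyphenyl in place of thiophen-3-yl on an aromatic carbon. Within the data shown here, the steps that bear on this change are a number 34.3 percentage points lower from compound 1 to compound 3 (beyond the scatter) and a number 30.4 percentage points higher from compound 2 to compound 3 (beyond the scatter); both swap the same position between a substituted phenyl and thiophen-3-yl and both are large, but they run in opposite directions, so a phenyl group here can land on either side of compound 3. A step of moderate size in either direction is therefore expected for a number 8.7 percentage points lower from compound 3 to compound 4 (within the scatter). For compound 4 the estimate in this assay is 55%, within 25% to 90%.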

Compound 4, a percentage reported as inhibition, at one concentration (the size of the read-out at that concentration, not a potency): 36.6%
For compound 4 the middle estimate is 18.4 percentage points above the measured one; the range from low to high includes it.
By their numbers in this assay, from the lowest: compounds 2 and 4 (each within the scatter of the next); then compound 3; then compound 1.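

In this assay, 2-methoxyphenyl at this position gives a number 27.1 percentage points lower from compound 3 to compound 4 (beyond the scatter) and a number 61.4 percentage points lower from compound 1 to compound 4 (beyond the scatter), while a number 3.3 percentage points higher from compound 2 to compound 4 (within the scatter). Of the three phenyl groups shown, 4-fluorophenyl and 2-methoxyphenyl both fall below thiophen-3-yl, and only 4-formylphenyl, in compound 1, lies above it. No measurement shown accounts for these differences. The compounds shown leave open whether the high reading of compound 1 is specific to the formyl group or would persist with a carboxylic acid or an amine in its place.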